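A biphenyl in place of a pyridine: what to expect

A few compounds are considered here, and "the series" means these few. Any claim that something is new, unique, unknown or untested is made for them only; others in the source may bear on it.

Compound 1 `CC(C)N(Cc1cccc(OCCCCCC(=O)O)c1)C(=O)c1ccc(-c2cccc(N(C)C)c2)cc1` was examined in an ADME assay on HEK293 cells (Homo sapiens) for cytotoxicity, read by CellTiter-Glo and resazurin assay, with a stated time of 72 h; a lower number here means that less compound is needed, a higher number that more compound is needed for the effect. In this assay compound 1 reaches only the limit > 26000 nM, which is not a number. Compound 2 `CC(C)N(Cc1cccc(OCCCCCC(=O)O)c1)C(=O)c1ccc(-c2ccncc2)cc1` differs from it in one place. In this assay compound 2 likewise stops at the limit > 26000 nM. Going by the values given here, the single step between measured compounds, a step that the two limits leave unreadable from compound 1 to compound 2, therefore cannot be read, and compound 2 stands where compound 1 stands, as the limit of > 26000 nM in this assay, at which 2 of the 2 values shown sit, records. Compound 3 `CC(C)N(Cc1cccc(OCCCCCC(=O)O)c1)C(=O)c1ccc(-c2cccc(-c3ccccc3)c2)cc1` has not yet been measured; it differs from compound 2 by 3-phenylphenyl in place of pyridin-4-yl on an aromatic carbon. Among the compounds with values here, no measured step bears on that change: the one step between measured compounds is unreadable, and both known values are limits. The account therefore expects in this assay no step beyond the scatter, with compound 3 most probably again stopping at the limit. For compound 3 in this assay the estimated half-maximal effective concentration is 26000 nM, between 8000 nM and 60000 nM. The expected step of a number no higher from compound 2 to compound 3 (the limit leaves the size open) is thus essentially none.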

Compound 3, half-maximal effective concentration: > 26000 nM
Compound 3 was reported as a limit; the forecaster's own chance of this, stated with the estimate: 70%; the middle value sits exactly at the limit.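

In this assay compound 3 stops at the limit > 26000 nM and gives no number. Going by these compounds alone, with compound 1 and compound 2 also reported as limits, no new step involving compound 3 can be read. The compounds shown leave open the concentration at which any of them would reach the half-maximal effect, for all three stand at one value: the limit of > 26000 nM in this assay, at which 3 of the 3 values shown sit.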